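The source may report more compounds than this note shows. Statements on the series, on what has been measured and on what is new or still open speak of the compounds shown alone.

Working notes on the series. All members share one core and differ only in the group on the nitrogen on the aromatic ring. For the measured compounds named here, compound 1 `COc1ccc(Nc2nc(-c3cccc(F)c3)nc3ccc(F)cc23)cc1` is the one member with a numerical reading: in a functional assay on U-937 cells (Homo sapiens) for cytotoxicity, read by MTT assay, with a stated time of 48 h (on this read-out higher numbers stand for weaker inhibition and lower numbers for stronger inhibition), compound 1 gives 41100 nM. Compound 2 `COc1ccccc1Nc1nc(-c2cccc(F)c2)nc2ccc(F)cc12` carries 2-methoxyphenyl in place of 4-methoxyphenyl; in this assay compound 2 returns only the assay limit, > 50000 nM. Compound 3 `Fc1ccc(Nc2nc(-c3cccc(F)c3)nc3ccc(F)cc23)cc1` carries 4-fluorophenyl; in this assay compound 3 likewise returns only the assay limit, > 50000 nM. Compound 3 thus stands at the floor of the assay together with one further member (the limit of > 50000 nM in this assay, at which 2 of the 3 values shown sit), and the steps of an at least 1.2-fold higher number from compound 1 to compound 3 (0.08 log units; that floor lies within the scatter) and a step that the two limits leave unreadable from compound 2 to compound 3 can only be read from that floor.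

Compound 4 `Fc1cccc(-c2nc(Nc3ccccc3F)c3cc(F)ccc3n2)c1` differs from compound 3 by 2-fluorophenyl in place of 4-fluorophenyl on a nitrogen on an aromatic ring. Going by the values given here, the one measured step of the same kind, a shift of the ring substituent, is an at least 1.2-fold higher number from compound 1 to compound 2 (0.08 log units; that floor lies within the scatter), which did not leave the scatter. Compound 4 is therefore expected to show no step beyond the scatter, a step that the limit leaves unreadable from compound 3 to compound 4, most likely as another limit. The estimate for compound 4 in this assay is 60000 nM, with a range from 30000 nM to 150000 nM.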

Compound 4, half-maximal inhibitory concentration: > 50000 nM
Compound 4: a limit, no number; the forecaster's own chance of this, stated with the estimate: 70%; the middle value lies beyond the limit too.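

With 2-fluorophenyl in place of 4-fluorophenyl on this nitrogen, compound 4 also returns only a limit in this assay, so neither placement of the fluoro group gives a numerical reading, and the steps among compound 2, compound 3 and compound 4 cannot be read. Against the one member with a number there is an at least 1.2-fold higher number from compound 1 to compound 4 (0.08 log units; that floor lies within the scatter), so compound 4 shows no separation from that member either. The series now gathers at one end of the scale: the limit of > 50000 nM in this assay, at which 3 of the 4 values shown sit.

On these data alone, how far compound 2, compound 3 and compound 4 each lie past the limit stays open. Also open, as far as these compounds go, is how an amine or a carboxylic acid on the phenyl ring, or a longer chain in place of that ring, would read in this assay.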